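A few compounds are considered here, and "the series" means these few. Any claim that something is new, unique, unknown or untested is made for them only; others in the source may bear on it.

Measured compounds:
compound 1 `CCn1cc(C(=O)O)c(=O)c2cc(F)c(N3CCN(C(=N)NS(=O)(=O)c4ccc(C)cc4)CC3)cc21` — 43 nM
compound 2 `N=C(NS(=O)(=O)c1ccccc1Cl)N1CCN(c2cc3c(cc2F)c(=O)c(C(=O)O)cn3C2CC2)CC1` — 43 nM

In a functional assay on HL-60 cells (Homo sapiens) for antiproliferative activity, read by MTT assay, with a stated time of 72 h (on this read-out higher numbers stand for weaker inhibition and lower numbers for stronger inhibition), compound 1 gives 43 nM and compound 2 gives 43 nM. The two values are level at the digits shown and lie within the usual scatter of one another, so nothing can be said about any order between them. Among the measured compounds shown here, the two compounds differ in more than one place, and no single step between measured compounds is available to guide a prediction.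

Compound 3 `CCn1cc(C(=O)O)c(=O)c2cc(F)c(N3CCN(C(=N)NS(=O)(=O)c4ccc(C(F)(F)F)cc4)CC3)cc21` has not yet been measured in this assay. It differs from compound 1 by trifluoromethyl in place of methyl on an aromatic carbon. For the measured compounds named here, no measured pair here tests that change, so the expectation rests on compound 1 alone, with the value 43 nM as the anchor. The step expected is a 1.0-fold higher number from compound 1 to compound 3 (0.02 log units; within the scatter), no larger than the scatter and in no particular direction. Compound 3 is therefore estimated at 45 nM, with a range from 18 nM to 110 nM.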

Compound 3, half-maximal inhibitory concentration: 43 nM
Estimate against measurement, compound 3: 1.0-fold (0.02 log units) above, and the stated range covers the measured number.
By their numbers in this assay, from the lowest: compounds 1, 2 and 3 (each within the scatter of the next).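

In this assay, the change from 4-methylphenyl to 4-(trifluoromethyl)phenyl gives no change at the digits printed from compound 1 to compound 3 (within the scatter). Among the compounds shown here, this is the first comparison here in which only one place differs, and it shows that this position can carry trifluoromethyl in place of methyl, a larger group by heavy-atom count, without a shift this read-out can detect; compounds 1 and 2 differ in more than one place and could not show that. Nothing measured here bears on the reason for this result.

From the compounds shown here alone, whether a different kind of group at this position, such as an amine, a carboxylic acid or a longer chain, would also leave the number in place remains open. Going by these compounds, it is also open whether the same swap would read alike on a compound with the cyclopropyl group that compound 2 carries in place of ethyl.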